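Swapping the Carbamate Side Chain: Expected Lipophilicity

The source may hold more compounds than are shown below. What is called first, only, known or untested is meant among the compounds shown, and "the series" means these compounds.

Values in a physicochemical assay for lipophilicity, using the shake flask method, measured as octanol-water partition, with a stated time of 15 min; a higher number here means a more lipophilic compound, a lower number a more polar compound:
Compound 1, `COC(=O)N[C@H](C)c1nc2ccc(F)cc2s1`, gives 2.5.
Compound 2, `CC(C)COC(=O)N[C@H](C)c1nc2ccc(F)cc2s1`, gives 4.24.
Compound 3, `C[C@@H](NC(=O)OC(C)(C)C)c1nc2ccc(F)cc2s1`, gives 4.41.

Compound 2 stands second highest of these three; a number 0.17 log units higher from compound 2 to compound 3 (within the scatter), whereas a number 1.74 log units higher from compound 1 to compound 2 (beyond the scatter). Compound 4, `C[C@@H](NC(=O)OCC(F)(F)F)c1nc2ccc(F)cc2s1`, differs from compound 2 by trifluoromethyl in place of isopropyl on a saturated chain carbon bound to an oxygen next to a carbonyl group. The large step from compound 1 to compound 2 shows how much the isopropyl contributed, and removing it should cost part of that; the incoming trifluoromethyl is expected to return some of the loss. A moderate drop in this assay is therefore expected, a number 0.84 log units lower from compound 2 to compound 4 (beyond the scatter). Compound 4 is estimated at 3.4, within 2.9 to 3.9.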

Compound 4, partition coefficient: 2.69
The estimate for compound 4 lay 0.71 log units above the measured number; the measured number lies below the stated range.
By their numbers in this assay, from the lowest: compounds 1 and 4 (each within the scatter of the next); then compounds 2 and 3 (each within the scatter of the next).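

In this assay, trifluoromethyl in place of isopropyl at this place gives a number 1.55 log units lower from compound 2 to compound 4 (beyond the scatter) even though the entering group has more heavy atoms, so atom count alone does not set the number here. The change from tert-butyl to 2,2,2-trifluoroethyl gives a number 1.72 log units lower from compound 3 to compound 4 (beyond the scatter) and agrees with this. Trifluoromethyl in place of hydrogen gives only a number 0.19 log units higher from compound 1 to compound 4 (within the scatter) and no data shown explain this contrast with isopropyl.

Open, from the compounds shown here alone, is whether a difluoromethyl group would give a number between those of compound 4 and compound 2. Going by these compounds, a longer fluorinated chain or an amine on this chain is equally open.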